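Methyl on the Saturated Ring: Expected Paw Edema Inhibition

The compounds below may be only part of what the source reports. "The series", "measured", "known", "first", "only" and "open" are said of these compounds alone.

Compound 1, `O=C(O)c1cc(-n2c(-c3ccccc3)cc3c2CCCC3)ccc1O`, in a functional assay on the whole organism (strain Wistar) for inhibition, with Rattus norvegicus as the target, read by paw edema, with stated times of 30 min and 3 h, at a dose of 200 mg/kg by the oral route (on this read-out higher numbers stand for more inhibition at the one dose given (going by the name of the read-out) and lower numbers for less inhibition), compound 1 gives >= 60%.
Compound 2, `CC(=O)Nc1cc(-n2c(-c3ccccc3)cc3c2CCCC3)cc(C(=O)O)c1O`, in this assay compound 2 gives 0%.
Compound 3, `COc1ccc(-c2cc3c(n2-c2ccc(O)c(C(=O)O)c2)CCCC3)cc1`, in this assay compound 3 gives 50%.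

The value for compound 1 is a limit of the assay, not a number, as the limit of >= 60% in this assay, at which 1 of the 3 values shown sits, records. Compound 4, `CC1CCc2c(cc(-c3ccccc3)n2-c2ccc(O)c(C(=O)O)c2)C1`, has not yet been measured. It differs from compound 1 in one place: methyl in place of hydrogen on a saturated ring carbon. Both measured steps concern a change on an aromatic carbon of compound 1. Putting an acetamido there gave a number at least 60 percentage points lower from compound 1 to compound 2 (beyond the scatter), a large drop. Putting a methoxy there gave a number at least 10 percentage points lower from compound 1 to compound 3 (that floor lies within the scatter). Neither step touches the saturated six-membered ring where the methyl of compound 4 enters, so they offer no direct guide. Without any evidence of a change at that ring, compound 4 is expected to remain close to compound 1, with a step of a number no higher from compound 1 to compound 4 (the limit leaves the size open), nothing beyond the scatter. Compound 4 is therefore estimated to reach 60%, most likely between 40% and 80%.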

Compound 4, a percentage reported as inhibition, in the whole organism at one dose (the size of the read-out at that dose, not a potency): 40%
For compound 4 the middle estimate is 20 percentage points above the measured one; the measured number falls inside the stated range.
By their numbers in this assay, from the lowest: compound 2; then compounds 4 and 3 (each within the scatter of the next). At a limit, above all of these: compound 1.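

In this assay, the saturated ring of the core turns out not to be a silent place: methyl in place of hydrogen on a saturated ring carbon gives a number at least 20 percentage points lower from compound 1 to compound 4 (beyond the scatter). Within the data shown here, the earlier steps concerned aromatic carbons only, so this is the first sign that the saturated ring also counts, even for a change of a single carbon. The step can be given only as a floor, because the value for compound 1 is a limit of the assay and not a number: the limit of >= 60% in this assay, at which 1 of the 4 values shown sits.

The compounds shown leave open what an ethyl group, a hydroxyl or an amine on that same ring carbon would do to the read-out. They also leave open whether a methyl on another carbon of the saturated ring would give a similar step.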